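Cyclopropyl to isopropyl on the nitrogen side chain

This account rests on a few compounds, and the source may have more. Where it says the series, first, only, none or still open, it means among the compounds named here.

The series shares one core and has two measured members. Compound 1 `COc1cc(N(CC2CC2)c2ccc(Cl)c(Cl)c2)cnc1C(=O)[C@H]1C[C@@H]1C(=O)O` carries a cyclopropylmethyl on the nitrogen on the aromatic ring together with a 3,4-dichlorophenyl; in an assay for inhibition of leukotriene C4 synthase (Homo sapiens), read by LC-MS, with stated times of 15 min and 30 min (a lower number here means a stronger inhibitor, a higher number a weaker inhibitor), compound 1 gives 4.94 nM. Compound 2 `COc1cc(N(CC2CC2)c2cccc(C(F)(F)F)c2)cnc1C(=O)[C@H]1C[C@@H]1C(=O)O` carries 3-(trifluoromethyl)phenyl instead, and in this assay compound 2 gives 6.42 nM. Within the data shown here, the step of a 1.3-fold higher number from compound 1 to compound 2 (0.11 log units; within the scatter) leaves the two values within the scatter of each other, so on the numbers so far nothing separates compound 2 from compound 1.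

Compound 3 `COc1cc(N(CC(C)C)c2cccc(C(F)(F)F)c2)cnc1C(=O)[C@H]1C[C@@H]1C(=O)O` differs from compound 2 at another place: isopropyl in place of cyclopropyl on a saturated chain carbon bound to a nitrogen on an aromatic ring, read one bond further out as cyclopropylmethyl to isobutyl. Among the measured compounds shown here, no measured step touches this position; the only step in hand, a 1.3-fold higher number from compound 1 to compound 2 (0.11 log units; within the scatter), concerns the aryl on the nitrogen and says nothing about the chain. The change removes the three-membered ring only. The expectation for compound 3 in this assay is therefore a step of about a 1.2-fold higher number from compound 2 to compound 3 (0.10 log units; within the scatter), not clearly beyond the scatter, with wide uncertainty. The estimate for compound 3 is 8 nM, expected between 3 nM and 25 nM.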

Compound 3, half-maximal inhibitory concentration: 4.74 nM
Compound 3: middle estimate off by 1.7-fold (0.23 log units), on the high side; the measured number falls inside the stated range.
By their numbers in this assay, from the lowest: compounds 3, 1 and 2 (each within the scatter of the next).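

Among these compounds, this is the first measured step at the chain on the nitrogen: in this assay the step of a 1.4-fold lower number from compound 2 to compound 3 (0.13 log units; within the scatter) stays within the scatter, so compound 2 and compound 3 cannot be told apart. With 3-(trifluoromethyl)phenyl on the nitrogen, the three-membered ring is therefore not required for potency at this level, since compound 3, with cyclopropylmethyl replaced by isobutyl, gives 4.74 nM in this assay without that ring. Neither the aryl change nor this chain change now separates its pair, and no measurement at hand bears on why the ring can go without a readable difference.

Among the compounds shown here, open is whether the same chain change holds with 3,4-dichlorophenyl on the nitrogen, as the only pair read at this position carries 3-(trifluoromethyl)phenyl. Also open is how much this position tolerates: a longer chain, or a chain ending in an amine or a hydroxyl group, might move the number beyond the scatter, and the compounds shown give no sign either way.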